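Dimethylated Thiophene on a Second Core: Expected Loss

The source may report more compounds than this note shows. Statements on the series, on what has been measured and on what is new or still open speak of the compounds shown alone.

Three measured compounds share a guanylhydrazone arm on a fused two-ring core and differ in the thiophene they carry and in the core itself. Compound 2 `Cc1cn2c(/C=N/NC(=N)N)c(-c3ccsc3)nc2s1` bears the plain thiophene, and in a functional assay on cells (Leukemia cell, Homo sapiens) for inhibition (a higher number here means a weaker inhibitor of growth, a lower number a stronger inhibitor of growth), compound 2 gives 7760 nM. Compound 1 `Cc1cc(-c2nc3sc(C)cn3c2/C=N/NC(=N)N)c(C)s1` carries the dimethylated thiophene on the same core, and in this assay compound 1 gives 47900 nM. The change between them, (2,5-dimethylthiophen-3-yl in place of thiophen-3-yl on an aromatic carbon), produced a 6.2-fold higher number from compound 2 to compound 1 (0.79 log units; beyond the scatter). Compound 3 `N=C(N)N/N=C/c1c(-c2ccsc2)nc2n1CCS2` has the plain thiophene on a different core; the difference between the two cores is not broken down here. In this assay compound 3 gives 19100 nM, a number lying between those of compound 2 and compound 1.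

Compound 4 `Cc1cc(-c2nc3n(c2/C=N/NC(=N)N)CCS3)c(C)s1` has not yet been measured. It differs from compound 3 by 2,5-dimethylthiophen-3-yl in place of thiophen-3-yl on an aromatic carbon. This is the same kind of change as that from compound 2 to compound 1, but the surroundings are not identical: in compound 3 the aromatic carbon also stands two ring bonds from two ring atoms that each bear a fused ring. For the measured compounds named here, only one measured example of this change exists, and the expectation rests on it. The step from compound 3 to compound 4 is expected to be a 5.8-fold higher number from compound 3 to compound 4 (0.76 log units; beyond the scatter), close to a 6.2-fold higher number from compound 2 to compound 1 (0.79 log units; beyond the scatter). Compound 4 is therefore estimated at 110000 nM. Compound 4 is expected to lie between 40000 nM and 300000 nM, a wide range. On these data alone, the change on this second core is untested, which keeps the range wide.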

Compound 4, concentration for 50% growth inhibition: 20900 nM
For compound 4 the middle estimate is 5.3-fold (0.72 log units) above the measured one; measured number outside the range, below it.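

In this assay, putting 2,5-dimethylthiophen-3-yl in place of thiophen-3-yl on the second core gives a 1.1-fold higher number from compound 3 to compound 4 (0.04 log units; within the scatter), so on this core the change leaves the growth inhibition without a readable shift. The rise in the number seen on the first core therefore did not carry over to the second, and the size of this change depends on the core it stands on, at least for these two pairs: the same change on two cores in this assay, a 6.2-fold higher number (0.79 log units; beyond the scatter) from compound 2 to compound 1 and a 1.1-fold higher number (0.04 log units; within the scatter) from compound 3 to compound 4, 5.6-fold (0.75 log units) apart, beyond the scatter of two such steps. This does not show which feature of the two cores separates the steps or why they differ, and one pair on each core gives no rule for predicting the step on any further core.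

The compounds shown leave open how a thiophene bearing a single methyl group would behave on either core, so it remains unknown whether one methyl group or both account for the rise on the first core. They also leave open whether a phenyl ring in place of the thiophene would show the same difference between the two cores.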